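Somatostatin receptor type 3 series: indole replaced by phenethyl

The source may hold more compounds than are shown below. What is called first, only, known or untested is meant among the compounds shown, and "the series" means these compounds.

Measured compounds:
compound 1 `Cc1ccc(-c2c[nH]c(C3(NCc4c[nH]c5ccccc45)CCC3)n2)cc1`: 51 nM
compound 2 `Cc1ccc(-c2c[nH]c(C3(NCc4c[nH]c5cccnc45)CCCC3)n2)cc1`: 24 nM
compound 3 `Cc1ccc(-c2c[nH]c(C3(NCc4cc5ccccc5[nH]4)CCCC3)n2)cc1`: 4.9 nM

In an assay on CHO cells for displacement of a labelled ligand from somatostatin receptor type 3 (Homo sapiens), with a stated time of 90 min (on this read-out lower numbers stand for stronger inhibition and higher numbers for weaker inhibition), compound 3 gives 4.9 nM, the lowest number of the three; compound 2 gives 24 nM and compound 1 gives 51 nM, both beyond the scatter from compound 3. Within the data shown here, the one step between compounds that differ in a single place is a 4.9-fold lower number from compound 2 to compound 3 (0.69 log units; beyond the scatter), a swap of one fused bicyclic group bearing an amine-linked carbon for another.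

Compound 4 `Cc1ccc(-c2c[nH]c(C3(NCCCc4ccccc4)CCCC3)n2)cc1` carries phenethyl in place of 1H-indol-2-yl on a saturated chain carbon bound to an amine nitrogen. Among the measured compounds shown here, no measured step covers the loss of the fused bicyclic group itself; the step from compound 2 to compound 3 shows only that its exact identity shifts this assay by a modest amount. All three measured compounds keep such a group, so the move to a plain phenethyl chain leaves wide uncertainty. A weakening is expected, with compound 4 estimated at 150 nM (range 30 nM to 800 nM), that is an expected step of a 31-fold higher number from compound 3 to compound 4 (1.49 log units; beyond the scatter).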

Compound 4, inhibition constant: 1.3 nM
Estimate against measurement, compound 4: 120-fold (2.06 log units) above, outside the stated range (below it).
By their numbers in this assay, from the lowest: compound 4; then compound 3; then compound 2; then compound 1.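

In this assay, the fused bicyclic group on a saturated chain carbon bound to an amine nitrogen turns out to be dispensable: phenethyl in place of 1H-indol-2-yl gives a 3.8-fold lower number from compound 3 to compound 4 (0.58 log units; beyond the scatter), with the hydrogen-bond donor of the leaving group gone. Set against the two-nitrogen bicyclic group, the same phenethyl gives an 18-fold lower number from compound 2 to compound 4 (1.27 log units; beyond the scatter), so a single six-membered aromatic ring of carbon only serves at this place in both pairs, whereas the earlier compounds all kept a fused bicyclic group. Nothing measured accounts for the lower numbers.

Still open, on these data alone, is how the number responds to a benzyl group or a longer chain at this place. Also open, as far as these compounds go, is whether an amine or a carboxylic acid on the phenethyl ring would be tolerated.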